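Moving the fluorine on the benzyl ester of an aminothiophene

This account rests on a few compounds, and the source may have more. Where it says the series, first, only, none or still open, it means among the compounds named here.

Compound 1 `COc1ccc(-c2csc(N)c2C(=O)Oc2ccccc2)cc1OC`: 48%
Compound 2 `COc1ccc(-c2csc(N)c2C(=O)OCc2ccc(C)cc2)cc1OC`: 50%
Compound 3 `COc1ccc(-c2csc(N)c2C(=O)OCc2ccccc2F)cc1OC`: 100%

Three esters of the shared core were tested in an assay on isolated protein for inhibition of protein kinase C zeta type (Homo sapiens), with stated times of 1 h and 2.5 min, tested at 30 uM; on this read-out lower numbers stand for less inhibition and higher numbers for more inhibition at the one concentration tested (going by the name of the read-out). Compound 3 stands highest of the three, with compound 2 nearest at a number 50 percentage points higher from compound 2 to compound 3 (beyond the scatter) and compound 1 furthest at a number 52 percentage points higher from compound 1 to compound 3 (beyond the scatter), both steps beyond the scatter; compound 1 and compound 2 lie within the scatter of each other (a number 2 percentage points higher from compound 1 to compound 2 (within the scatter)).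

Compound 4 `COc1ccc(-c2csc(N)c2C(=O)OCc2ccc(F)cc2)cc1OC` differs from compound 3 by 4-fluorophenyl in place of 2-fluorophenyl on a saturated chain carbon bound to an oxygen next to a carbonyl group. The step from compound 2 to compound 3, which also exchanged a 4-substituted for a 2-substituted benzyl, was large and upward, so the reverse kind of change is expected to lower the read-out, perhaps by less. Compound 4 is therefore estimated at 65% (range 35% to 95%), meaning an expected a number 35 percentage points lower from compound 3 to compound 4 (beyond the scatter).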

Compound 4, a percentage reported as inhibition, at one concentration (the size of the read-out at that concentration, not a potency): 2%
Beside the measured number, compound 4's estimate is 63 percentage points above it, outside the stated range (below it).
By their numbers in this assay, from the lowest: compound 4; then compounds 1 and 2 (each within the scatter of the next); then compound 3.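

In this assay, the place of the fluorine on the benzyl ester spans nearly the whole range seen so far: the same atoms, joined differently, give a number 98 percentage points lower from compound 3 to compound 4 (beyond the scatter). The group on the 4-substituted benzyl also matters, as fluoro in place of methyl gives a number 48 percentage points lower from compound 2 to compound 4 (beyond the scatter). With a number 46 percentage points lower from compound 1 to compound 4 (beyond the scatter), a benzyl ester does not by itself keep the read-out at or above that of the phenyl ester, while compound 3 goes the other way.

Nothing available here explains these differences.
Going by these compounds, whether 3-fluorobenzyl, 2-chlorobenzyl or an amide in place of the ester would resemble compound 3 or compound 4 remains open.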